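Swapping Diethylamino for Piperidinyl on the Methyl Core

This account rests on a few compounds, and the source may have more. Where it says the series, first, only, none or still open, it means among the compounds named here.

Compound 1 `CCN(CC)CCNc1n[n+]([O-])c2ccc(Cl)cc2[n+]1[O-]` and compound 2 `[O-][n+]1nc(NCCN2CCCCC2)[n+]([O-])c2cc(Cl)ccc21` share a chloro-bearing core and differ only in the chain amine: piperidin-1-yl in place of diethylamino on a saturated chain carbon, two bonds along the chain from a nitrogen on an aromatic ring. In a physicochemical assay for solubility, in the presence of a further agent that is not named here (a higher number here means a more soluble compound, a lower number a less soluble compound), compound 1 gives 23000000 nM. In this assay compound 2 gives 3200000 nM. That change produced a 7.2-fold lower number from compound 1 to compound 2 (0.86 log units; beyond the scatter).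

Compound 3 `CCN(CC)CCNc1n[n+]([O-])c2ccc(C)cc2[n+]1[O-]` differs from compound 1 in the core alone: methyl in place of chloro on an aromatic carbon. In this assay compound 3 reaches only a limit of the assay, > 49000000 nM. The step of an at least 2.1-fold higher number from compound 1 to compound 3 (0.32 log units; beyond the scatter) is therefore known only as a bound, because compound 3 sits at the limit of > 49000000 nM in this assay, at which 1 of the 3 values shown sits.

Compound 4 `Cc1ccc2c(c1)[n+]([O-])c(NCCN1CCCCC1)n[n+]2[O-]` carries, relative to compound 3, the same change that compound 2 carries relative to compound 1: piperidin-1-yl in place of diethylamino on a saturated chain carbon, two bonds along the chain from a nitrogen on an aromatic ring. The place of the change is the same in both pairs. On the methyl core the step is expected to be of similar size, an at least 4.9-fold lower number from compound 3 to compound 4 (0.69 log units; beyond the scatter), resting on the measured step of a 7.2-fold lower number from compound 1 to compound 2 (0.86 log units; beyond the scatter). Since compound 3 is known only through (the limit of > 49000000 nM in this assay, at which 1 of the 3 values shown sits), the starting point is itself uncertain. Compound 4 is therefore estimated at 10000000 nM, expected between 3000000 nM and 49000000 nM.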

Compound 4, solubility: 45000000 nM
Compound 4: the middle estimate sits 4.5-fold (0.65 log units) below what was measured; the measured number falls inside the stated range.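

On the chloro-bearing core, piperidin-1-yl in place of diethylamino gave a 7.2-fold lower number from compound 1 to compound 2 (0.86 log units; beyond the scatter), whereas on the methyl core the same change reads only as an at least 1.0-fold lower number from compound 3 to compound 4 (0.03 log units; that floor lies within the scatter), a floor that does not fix the size of the step. In this assay, on these data alone, compound 3 stands at a limit (> 49000000 nM), and the step on the methyl core stays open because of that limit: the limit of > 49000000 nM in this assay, at which 1 of the 4 values shown sits. With piperidin-1-yl held on the chain, methyl in place of chloro gives a 14-fold higher number from compound 2 to compound 4 (1.15 log units; beyond the scatter), yet the series does not show whether the change of amine carries from one core to the other at the same size or at a smaller one.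

The compounds shown leave open how the change of amine behaves on a core bearing fluoro or methoxy in place of chloro or methyl. They also leave open whether a morpholin-4-yl or pyrrolidin-1-yl group on the chain would follow piperidin-1-yl.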